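This account rests on a few compounds, and the source may have more. Where it says the series, first, only, none or still open, it means among the compounds named here.

Working notes on the series. Compound 1 `C[C@H](NC(=O)Nc1cccc(C(F)(F)F)c1)c1ccccc1` gives 94% in an ADME assay on the whole organism with Oryza sativa as the target, tested at 0.1 uM; on this read-out lower numbers stand for a stronger effect and higher numbers for a weaker effect at the one concentration tested. Compound 2 `C[C@H](NC(=O)Nc1cccc(F)c1)c1ccccc1` gives 97% in this assay. Among the compounds with values here, the only measured step between them is a number 3 percentage points higher from compound 1 to compound 2 (within the scatter). Within the data shown here, on the two numbers known so far, compound 1 stands with the lowest value, its nearest neighbour being compound 2 within the scatter, so no order between the two is claimed.

Compound 3 `C[C@H](NC(=O)Nc1cc(C(F)(F)F)cc(C(F)(F)F)c1)c1ccccc1` is not yet measured. It differs from compound 1 by trifluoromethyl in place of hydrogen on an aromatic carbon. Among the measured compounds shown here, the one measured step, a number 3 percentage points higher from compound 1 to compound 2 (within the scatter), bears on it only loosely: it exchanged a trifluoromethyl for a fluoro and moved the read-out by less than the scatter, so variation among fluorinated groups on the shared core has so far left this assay essentially unchanged. For the measured compounds named here, no measured step adds a group in place of hydrogen, so the direction of a second trifluoromethyl remains open. The expected step of a number 3 percentage points lower from compound 1 to compound 3 (within the scatter) is therefore small, with no change beyond the scatter expected. For compound 3 the estimate in this assay is 91%, within the range 76% to 100%.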

Compound 3, a percentage reported as activity, at one concentration (the size of the read-out at that concentration, not a potency): 101%
The estimate for compound 3 lay 10 percentage points below the measured number; the measured number lies above the stated range.
By their numbers in this assay, from the lowest: compounds 1, 2 and 3 (each within the scatter of the next).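

Trifluoromethyl in place of hydrogen on an aromatic carbon, meta to a large group and meta to a trifluoromethyl group, is the first step in the series that adds a group rather than exchanging one, and in this assay it gives a number 7 percentage points higher from compound 1 to compound 3 (within the scatter). The entering group brings 4 heavy atoms, yet the step stays within the scatter, so at this position a second trifluoromethyl leaves the read-out without a resolved change from that of compound 1. The measured data offer no independent information that would account for this result.

From the compounds shown here alone, all substituents varied on this ring so far are fluorine-containing, so it remains open whether an amine, a carboxylic acid, a methoxy group or a longer alkyl chain at the same position would move this assay beyond the scatter. Going by these compounds, it also remains open whether any change in this assay can be resolved through substitution on this ring at all, or whether a step of that size would require a change elsewhere on the shared core.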